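A Sulfur-for-Methyl Swap on a Nucleoside Core

The source may hold more compounds than are shown below. What is called first, only, known or untested is meant among the compounds shown, and "the series" means these compounds.

Three related nucleoside-like compounds have been tested in an ADME assay on L6 cells (Rattus norvegicus) for cytotoxicity; on this read-out lower numbers stand for stronger inhibition and higher numbers for weaker inhibition. Compound 1 `CNc1ncnc2c1ncn2[C@@H]1O[C@H](C)[C@@H](O)[C@H]1O` gives 266000 nM. Compound 2 `CNc1ncnc2c1ncn2[C@@H]1O[C@H](SC)[C@@H](O)[C@H]1O` carries methylsulfanyl in place of methyl on a saturated ring carbon relative to compound 1; in this assay compound 2 gives 159000 nM, and the step is a 1.7-fold lower number from compound 1 to compound 2 (0.22 log units; within the scatter). Compound 3 `CNc1nc(I)nc2c1ncn2[C@@H]1O[C@H](C)[C@@H](O)[C@H]1O` has a different core, the difference being (iodo in place of hydrogen on an aromatic carbon); compound 3 gives 137000 nM, and the step is a 1.9-fold lower number from compound 1 to compound 3 (0.29 log units; within the scatter). Among the compounds with values here, the three values sit so close together that no compound can be called more or less cytotoxic than another.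

Compound 4 `CNc1nc(I)nc2c1ncn2[C@@H]1O[C@H](SC)[C@@H](O)[C@H]1O` has not yet been measured. It differs from compound 3 by methylsulfanyl in place of methyl on a saturated ring carbon. This is the same change that links compound 1 to compound 2: the surroundings of the altered carbon are described in identical words for both pairs, so the two changes are the same. Within the data shown here, the only guide to its effect is the earlier step, which was a 1.7-fold lower number from compound 1 to compound 2 (0.22 log units; within the scatter) and lay within the scatter. A step of similar small size is expected, a 1.6-fold lower number from compound 3 to compound 4 (0.21 log units; within the scatter). This rests on a single pair of compounds, so the expectation is loose. Compound 4 is therefore estimated at 85000 nM. The expected range for compound 4 runs from 35000 nM to 200000 nM.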

Compound 4, half-maximal inhibitory concentration: 120000 nM
Beside the measured number, compound 4's estimate is 1.4-fold (0.15 log units) below it, and the stated range covers the measured number.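

In this assay the new compound adds two steps: the methylsulfanyl change on the iodo-bearing core gives a 1.1-fold lower number from compound 3 to compound 4 (0.06 log units; within the scatter), and the iodo change on the methylsulfanyl-bearing core gives a 1.3-fold lower number from compound 2 to compound 4 (0.12 log units; within the scatter), so neither step shows that the change does anything to the number. Set beside its earlier counterpart, the methylsulfanyl change looks no different on the two cores, which means that what carries over is only the lack of a clear effect: the same change on two cores in this assay, a 1.7-fold lower number (0.22 log units; within the scatter) from compound 1 to compound 2 and a 1.1-fold lower number (0.06 log units; within the scatter) from compound 3 to compound 4, 1.5-fold (0.17 log units) apart, within the scatter of two such steps. The iodo change reads the same way, but two pairs whose steps all lie within the scatter cannot show that a change with a clear effect would carry from one core to the other: the same change on two cores in this assay, a 1.9-fold lower number (0.29 log units; within the scatter) from compound 1 to compound 3 and a 1.3-fold lower number (0.12 log units; within the scatter) from compound 2 to compound 4, 1.5-fold (0.17 log units) apart, within the scatter of two such steps.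

On these data alone, only methyl and methylsulfanyl appear on the saturated ring carbon, and only hydrogen and iodo on the aromatic carbon, so it remains open whether a longer chain such as ethylsulfanyl, an amine at the ring carbon, or a chloro or bromo group on the aromatic carbon would produce a step beyond the scatter. If one did, the same pairing across both cores would give a far sharper test of whether the effect carries over.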